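A few compounds are considered here, and "the series" means these few. Any claim that something is new, unique, unknown or untested is made for them only; others in the source may bear on it.

Working notes on the series.

Compound 1 `CCNCc1cn(Cc2ccccc2)c2ccccc12` is an unusual member: in an assay on isolated protein for inhibition of Amine oxidase [flavin-containing] B (Rattus norvegicus) (a lower number here means a stronger inhibitor, a higher number a weaker inhibitor), compound 1 gives 429000 nM. Compound 2 `C#CCN(C)Cc1cc2ccccc2n1C` gives 3 nM in this assay, and compound 3 `CC#CCN(C)Cc1cc2ccccc2n1C` gives 30 nM. The difference between the core of compound 1 and that of compound 2 is not broken down here; the two values show compound 1 far weaker than either.

One matched step is measured. From compound 2 to compound 3 the change is methyl in place of hydrogen on a triple-bonded carbon, and it gave a 10-fold higher number from compound 2 to compound 3 (1.00 log units; beyond the scatter).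

Compound 4 `CC(C)NCc1cn(Cc2ccccc2)c2ccccc12` is yet to be measured. It differs from compound 1 by methyl in place of hydrogen on a saturated chain carbon bound to an amine nitrogen and a saturated chain carbon: the same kind of change as in the earlier pair, but the place differs, there on a triple-bonded carbon, here on a saturated chain carbon bound to an amine nitrogen and a saturated chain carbon. Given that difference in place, and that compound 1 already sits at 429000 nM, a smaller loss than the earlier step is expected, roughly a 1.6-fold higher number from compound 1 to compound 4 (0.21 log units; within the scatter). For compound 4 in this assay the estimate is 700000 nM, with the plausible span from 200000 nM to 2500000 nM.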

Compound 4, inhibition constant: 438000 nM
Beside the measured number, compound 4's estimate is 1.6-fold (0.20 log units) above it; the range from low to high includes it.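

In this assay, methyl in place of hydrogen on a saturated chain carbon bound to an amine nitrogen and a saturated chain carbon gives a 1.0-fold higher number from compound 1 to compound 4 (0.01 log units; within the scatter), so ethylamino and isopropylamino are not told apart on the core of compound 1. Set beside the step on a triple-bonded carbon, the size of a methyl-for-hydrogen step does not carry over between these two pairs: the same change on two cores in this assay, a 10-fold higher number (1.00 log units; beyond the scatter) from compound 2 to compound 3 and a 1.0-fold higher number (0.01 log units; within the scatter) from compound 1 to compound 4, 9.8-fold (0.99 log units) apart, beyond the scatter of two such steps The two pairs differ in the place of the methyl as well as in the core, and each is a single pair, so the comparison does not show whether core or place sets the gap, nor does it give a rule for the series.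

Open, on these data alone, is whether a tert-butyl or a longer chain in place of the isopropyl of compound 4 would stay level with compound 1. Also open, as far as these compounds go, is what step a methyl on a saturated chain carbon would give on the core of compound 2.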